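This account rests on a few compounds, and the source may have more. Where it says the series, first, only, none or still open, it means among the compounds named here.

The measured compounds are:

- compound 1, `N#CC1=C(N)Oc2c(c3nc4ccccc4nc3c3ccccc23)C12C(=O)N(Cc1cnnn1-c1ccc(Cl)cc1)c1ccccc12`; in a functional assay on HepG2 cells (Homo sapiens) for antiproliferative activity, read by MTT assay, with a stated time of 48 h (on this read-out higher numbers stand for weaker inhibition and lower numbers for stronger inhibition), compound 1 gives > 50000 nM, which is a limit of the assay and not a number.
- compound 2, `COc1ccc(-n2nncc2CN2C(=O)C3(C(C#N)=C(N)Oc4c3c3nc5ccccc5nc3c3ccccc43)c3ccccc32)cc1`; in this assay compound 2 gives > 50000 nM, again a limit rather than a number.

Compound 1 therefore stands at the ceiling of what this assay reports: both values shown sit there, as the limit of > 50000 nM in this assay, at which 2 of the 2 values shown sit, records. Among the compounds with values here, the only measured step, a step that the two limits leave unreadable from compound 1 to compound 2, cannot be read in size or direction, since a limit on each side hides any difference that a methoxy in place of chloro on an aromatic carbon might have made.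

Compound 3, `N#CC1=C(N)Oc2c(c3nc4ccccc4nc3c3ccccc23)C12C(=O)N(Cc1cnnn1-c1ccc(N)cc1)c1ccccc12`, differs from compound 1 by amino in place of chloro on an aromatic carbon. Within the data shown here, no measured step shows the effect of an amino at this position, and the one step that exists between compound 1 and compound 2 is itself unreadable. With nothing to suggest that compound 3 would move off the ceiling, the expectation is a step of a number no higher from compound 1 to compound 3 (the limit leaves the size open), that is, no change beyond the scatter. Compound 3 is accordingly estimated at 50000 nM, with a range from 20000 nM to 100000 nM, and most likely reported again only as a limit.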

Compound 3, half-maximal inhibitory concentration: > 50000 nM
Compound 3 ended at the assay's limit; the forecaster's own chance of this, stated with the estimate: 80%; the middle value sits exactly at the limit.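

In this assay compound 3 gives > 50000 nM, which is a limit of the assay and not a number. Neither its step from compound 1 nor its step from compound 2 can be read. The compounds shown all sit at one ceiling: the limit of > 50000 nM in this assay, at which 3 of the 3 values shown sit. They leave open whether any group at this place would bring a measurable value.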